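This account rests on a few compounds, and the source may have more. Where it says the series, first, only, none or still open, it means among the compounds named here.

Measured so far:
- compound 1 `CCNC(=O)c1cc(Oc2ccc(NC(=O)c3cc4cccnc4n(-c4ccccc4)c3=O)cc2)ccn1`: in a functional assay on A549 cells (Homo sapiens) for antiproliferative activity, read by MTT assay, with a stated time of 72 h (a lower number here means a stronger inhibitor, a higher number a weaker inhibitor), compound 1 gives 160 nM
- compound 2 `CCCNC(=O)c1cc(Oc2ccc(NC(=O)c3cc4cccnc4n(-c4ccccc4)c3=O)cc2)ccn1`: compound 2 gives 95 nM

Going by the values given here, compound 2 carries the lowest of the two numbers in this assay, with compound 1 the nearest; the only measured step is a 1.7-fold lower number from compound 1 to compound 2 (0.23 log units; within the scatter), which lies within the scatter, so the two compounds cannot be ordered.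

Compound 3 `CCCNC(=O)c1cc(Oc2ccc(NC(=O)c3cc4cccnc4n(-c4ccc(Br)cc4)c3=O)cc2)ccn1` is the next member: the change from compound 2 is bromo in place of hydrogen on an aromatic carbon. Among the compounds with values here, no measured step touches this position; the one known step concerns the propyl chain on the other amide and says nothing about the phenyl ring. With no bearing evidence, the default expectation is no step beyond the scatter in this assay, in either direction, with a wide range to reflect the lack of precedent.

Compound 3 is therefore expected to give 90 nM (range 35 nM to 250 nM), an estimated step of a 1.1-fold lower number from compound 2 to compound 3 (0.02 log units; within the scatter).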

Compound 3, half-maximal inhibitory concentration: 150 nM
Compound 3: the middle estimate sits 1.7-fold (0.22 log units) below what was measured, within the range that was stated.
By their numbers in this assay, from the lowest: compounds 2, 3 and 1 (each within the scatter of the next).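

Going by these compounds alone, the change from phenyl to 4-bromophenyl gives the first reading on this ring, as the earlier compounds varied only the saturated chain on the other amide. In this assay the step is a 1.6-fold higher number from compound 2 to compound 3 (0.20 log units; within the scatter), so a single bromine on this aromatic carbon, para to a large group, produces no change that can be told from the scatter. No outside data bear on this step.

Since bromo is the only group shown here, it remains open whether an amine, a carboxylic acid or a methoxy group at this carbon would give a step beyond the scatter. As far as these compounds go, it also remains open whether bromo would give a similar step when paired with the ethyl amide of compound 1 rather than the propyl amide of compound 2.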